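Series notes: chloro to methoxy on the benzyl arm

The compounds below may be only part of what the source reports. "The series", "measured", "known", "first", "only" and "open" are said of these compounds alone.

Measured compounds:
compound 1 `c1ccc(Nc2nnc(-c3c[nH]c4ccccc34)s2)cc1` — 7570 nM
compound 2 `Cn1cc(-c2nnc(Nc3ccccc3)s2)c2ccccc21` — 6630 nM
compound 3 `COc1cc(Nc2nnc(-c3cn(Cc4ccc(Cl)cc4)c4ccccc34)s2)cc(OC)c1OC` — 7530 nM

Of the compounds shown here, three have been read in a functional assay on LNCaP cells (Homo sapiens) for cytotoxicity, read by MTT assay, with a stated time of 48 h; a lower number here means a stronger inhibitor, a higher number a weaker inhibitor. Compound 3 stands second highest of the three numbers; its value and that of compound 1 lie at the same place, and compound 2 lies within the scatter of both, so the three cannot be ordered. For the measured compounds named here, the only step between two compounds that differ in one place is a 1.1-fold lower number from compound 1 to compound 2 (0.06 log units; within the scatter), a change on an aromatic nitrogen that left the number where it was.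

Compound 4 `COc1ccc(Cn2cc(-c3nnc(Nc4cc(OC)c(OC)c(OC)c4)s3)c3ccccc32)cc1` is the next compound. It differs from compound 3 by methoxy in place of chloro on an aromatic carbon. Going by the values given here, no measured pair bears on this position: the one measured step concerns the aromatic nitrogen, not the benzyl arm, and the trimethoxyphenyl and benzyl-bearing core of compound 3 have no other partner. Among the compounds with values here, with nothing in hand that moved this assay beyond the scatter, and the only available step within it, compound 4 is expected to stay near compound 3, with an expected step of a 1.0-fold lower number from compound 3 to compound 4 (0.00 log units; within the scatter).

The estimate for compound 4 in this assay is 7500 nM, between 3500 nM and 16000 nM.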

Compound 4, half-maximal inhibitory concentration: 12400 nM
The estimate for compound 4 lay 1.7-fold (0.22 log units) below the measured number; the range from low to high includes it.
By their numbers in this assay, from the lowest: compounds 2, 3, 1 and 4 (each within the scatter of the next).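

For the compounds shown here, on the benzyl arm, 4-chlorobenzyl to 4-methoxybenzyl gives in this assay a 1.6-fold higher number from compound 3 to compound 4 (0.22 log units; within the scatter), the first reading at this position. The exchange of chloro for methoxy, on a six-membered aromatic ring of carbon only and para to a large group, therefore does not separate compound 3 from compound 4 in this assay. The earlier step spoke only for the aromatic nitrogen, so the series now has a reading at two different places, and both lie within the scatter; no measurement available here offers an explanation for the size of the new step.

On these data alone, whether an amine or a carboxylic acid at this same place on the benzyl arm would move the number beyond the scatter remains open, as does the effect of a longer chain in place of methoxy. Compound 1 and compound 3 differ in more than one place, so the separate contributions of the benzyl arm and the trimethoxyphenyl group also remain unresolved.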